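Amide Exchange on a Shared Core: Compound 4 Expected

The source may report more compounds than this note shows. Statements on the series, on what has been measured and on what is new or still open speak of the compounds shown alone.

Compound 1 `COc1ccc(OC)c(-c2cc(-c3ccc(C(=O)N(C)Cc4ccccc4)s3)on2)c1` gives > 30000 nM in a functional assay on A549 cells (Homo sapiens) for cytotoxicity, read by XTT assay, with a stated time of 72 h; a higher number here means a weaker inhibitor, a lower number a stronger inhibitor.
Compound 2 `COc1ccc(OC)c(-c2cc(-c3ccc(C(=O)NC4CC4)s3)on2)c1` gives > 30000 nM.
Compound 3 `COc1ccc(OC)c(-c2cc(-c3ccc(C(=O)N(C)Cc4ccc(F)cc4)s3)on2)c1` gives > 30000 nM.

Each of these three values is a limit of the assay rather than a measured number. Going by the values given here, compound 3 therefore stands at a limit, and so do the two others, so no compound can be placed above or below another. The three share one core and differ only in the group attached to the carbonyl carbon. The three measured steps, a step that the two limits leave unreadable from compound 1 to compound 2, a step that the two limits leave unreadable from compound 1 to compound 3 and a step that the two limits leave unreadable from compound 2 to compound 3, cannot be read in size, since all three values sit at the limit of > 30000 nM in this assay, at which 3 of the 3 values shown sit.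

The next compound, compound 4 `COc1ccc(OC)c(-c2cc(-c3ccc(C(=O)N4CCCC4)s3)on2)c1`, changes the same position once more: pyrrolidin-1-yl in place of (4-fluorobenzyl)(methyl)amino on a carbonyl carbon. Among the compounds with values here, the steps that bear on this change are the three above, and none of them showed a readable size in this assay. With no exchange on the carbonyl carbon yet having lifted any compound off the limit, compound 4 is expected to remain at that limit as well, with an estimated value of 30000 nM and a range from 10000 nM to 100000 nM. The expected step of a number no higher from compound 3 to compound 4 (the limit leaves the size open) is thus not one that the assay would be expected to resolve.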

Compound 4, half-maximal inhibitory concentration: > 30000 nM
Compound 4: only a limit was reported (the forecaster's own chance of this, stated with the estimate: 85%); the middle value lies on the limit itself.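

No step from compound 4 to compound 1, compound 2 or compound 3 can be read, because each of the four values is a limit and not a measured number: the limit of > 30000 nM in this assay, at which 4 of the 4 values shown sit.

The compounds shown leave open whether any group on the carbonyl carbon of the shared core gives a readable value in this assay, and how large a step between these groups would be.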